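Fluorine on the benzoyl ring of an mGlu5 modulator

The compounds below may be only part of what the source reports. "The series", "measured", "known", "first", "only" and "open" are said of these compounds alone.

Compound 1, `O=C(C1CCC1)N1CCCn2nc(COc3ccccc3)cc21`, and compound 2, `O=C(c1ccccc1)N1CCCn2nc(COc3ccccc3)cc21`, share one core and differ only in the group on the carbonyl carbon. In a functional assay on HEK293 cells for positive allosteric modulation of metabotropic glutamate receptor 5 (Homo sapiens), read by calcium flux (on this read-out lower numbers stand for smaller maximal responses and higher numbers for larger maximal responses), compound 1 gives 41%, while compound 2 gives 63%. Among the compounds with values here, the single measured step, a number 22 percentage points higher from compound 1 to compound 2 (beyond the scatter), places phenyl in place of cyclobutyl on the carbonyl carbon. Within the data shown here, compound 2 therefore stands highest of the two numbers known, with compound 1 the nearest and lower.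

Compound 3, `O=C(c1cccc(F)c1)N1CCCn2nc(COc3ccccc3)cc21`, keeps the phenyl of compound 2 and adds one atom: fluoro in place of hydrogen on an aromatic carbon. Among the measured compounds shown here, no measured step touches this kind of change, since the only step recorded swaps a whole ring for another and says nothing about a single fluorine on an aromatic carbon. With no guide pointing either way, the expectation is that compound 3 stays close to compound 2, a step of a number 2 percentage points higher from compound 2 to compound 3 (within the scatter), within the scatter. In this assay compound 3 is thus estimated at 65%, with a range from 45% to 85%.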

Compound 3, largest response reached (reported as percent of maximum), in percent of the reference or control that the assay uses: 61%
Estimate against measurement, compound 3: 4 percentage points above, within the range that was stated.
By their numbers in this assay, from the lowest: compound 1; then compounds 3 and 2 (each within the scatter of the next).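

In this assay, the change from hydrogen to fluoro on this aromatic carbon, meta to a large group, gives a small step (a number 2 percentage points lower from compound 2 to compound 3 (within the scatter)), so this carbon of the phenyl ring can carry a fluorine with no change that stands out from the usual variation between repeats. The advantage of an aromatic ring over cyclobutyl on the carbonyl carbon also remains with the fluorine in place (a number 20 percentage points higher from compound 1 to compound 3 (beyond the scatter)), which shows that this advantage is not confined to the unsubstituted phenyl of compound 2. No independent evidence bears on why the fluorine makes so little difference here.

The compounds shown leave open whether a bulkier group on this same carbon, such as methoxy, trifluoromethyl or an amine, would hold the response as fluoro does, and whether fluoro on a different carbon of the ring would behave the same way. They also leave open how other rings on the carbonyl carbon, such as pyridine or thiophene, would compare with phenyl and 3-fluorophenyl.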